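Anilide variation at the chain end of the triazole series

This account rests on a few compounds, and the source may have more. Where it says the series, first, only, none or still open, it means among the compounds named here.

Compound 1 `Cn1c(Cc2nn(C)c(=O)c3ccccc23)nnc1SCCCCCCCC(=O)Nc1ccc(F)cc1F` carries a 2,4-difluorophenyl group on the amide nitrogen; in an assay on isolated protein for binding affinity to interleukin-15 (Homo sapiens), read by surface plasmon resonance (a higher number here means weaker binding, a lower number tighter binding), compound 1 stands at "not determined" (no result reported), so no number is available for it. Within the data shown here, compound 2 `Cn1c(Cc2nn(C)c(=O)c3ccccc23)nnc1SCCCCCCCC(=O)Nc1ccc(Cl)cc1Cl` is the only member of the series with a number in this assay: compound 2 gives 19100 nM, which places it as a weak binder and is the sole reference point available. Compound 3 `COc1ccc(NC(=O)CCCCCCCSc2nnc(Cc3nn(C)c(=O)c4ccccc34)n2C)cc1` is not yet measured. The change from compound 2 to compound 3 is 4-methoxyphenyl in place of 2,4-dichlorophenyl on an amide-type nitrogen. Among the measured compounds shown here, no pair of measured compounds differing in one place exists here, so no measured step can be drawn on. Given the weak binding of compound 2 at 19100 nM and a change that only exchanges one aryl group on the amide-type nitrogen for another of the same size, the expected step of a 1.3-fold higher number from compound 2 to compound 3 (0.12 log units; within the scatter) is small, most likely within the scatter or a modest loss. Compound 3 is therefore estimated at 25000 nM in this assay, with a range from 8000 nM to 80000 nM.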

Compound 3, dissociation constant: 26000 nM
Compound 3: middle estimate off by 1.0-fold (0.02 log units), on the low side; the measured number falls inside the stated range.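

In this assay, among these compounds, the exchange of 2,4-dichlorophenyl for 4-methoxyphenyl on the amide-type nitrogen gives a 1.4-fold higher number from compound 2 to compound 3 (0.13 log units; within the scatter), the first measured step at this position. For this pair, the two aryl groups cannot be told apart in binding, even though the entering group brings oxygen and a hydrogen-bond acceptor while the leaving group brings chlorine and no acceptor, so this single exchange gives no handle for tighter binding. No measurement shown here explains this result or connects it to any property of either group.

Compound 1 has no number, so steps involving its 2,4-difluorophenyl group cannot be read, and a single pair within the scatter cannot show whether the aryl position matters at all for binding. On these data alone, it remains open whether an amine or a carboxylic acid on the aryl ring, a longer chain between the sulfur and the amide carbonyl, or a change to the shared core would move the number beyond the scatter.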